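The compounds below may be only part of what the source reports. "The series", "measured", "known", "first", "only" and "open" are said of these compounds alone.

Compound 1 `N#C[Se]c1ccc(NC(=O)CCC(=O)O)cc1` was tested in a functional assay on HepG2 cells (Homo sapiens) for cytotoxicity, read by MTT assay, with a stated time of 48 h (on this read-out higher numbers stand for weaker inhibition and lower numbers for stronger inhibition), and there compound 1 gives "not active" (no number reported), so no single number marks where it stands. Two related compounds supply the numbers that exist. Compound 2 `O=C(O)/C=C\C(=O)Nc1ccc([Se][Se]c2ccc(NC(=O)/C=C\C(=O)O)cc2)cc1` gives 3000 nM in this assay, and compound 3 `O=C1CCCC(=O)N1c1ccc([Se][Se]c2ccc(N3C(=O)CCCC3=O)cc2)cc1` gives 35000 nM; the two values lie well apart, with compound 2 the lower of the pair. Compound 4 `N#C[Se]c1ccc(NC(=O)/C=C\C(=O)O)cc1` has not yet been measured. It differs from compound 1 in one place (2-carboxyethenyl in place of 2-carboxyethyl on a carbonyl carbon). The same 2-carboxyethenyl group is carried by compound 2, whose value is the lower of the two numbers that exist. Among the measured compounds shown here, no measured pair shows this exact change, so the size of the step cannot be read from the data. Because compound 1 gives "not active" (no number reported), compound 4 is expected to move toward a measurable value, while the chance remains considerable that it too is reported only as not active. Compound 4 is expected to give about 30000 nM in this assay, within a range from 5000 nM to 150000 nM.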

Compound 4, half-maximal inhibitory concentration: 5000 nM
The estimate for compound 4 lay 6.0-fold (0.78 log units) above the measured number; low and high end bracket the measured number.
By their numbers in this assay, from the lowest: compounds 2 and 4 (each within the scatter of the next); then compound 3.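

Among the compounds shown here, compound 1 has no number in this assay, so no step from it to compound 4 can be read. The compounds shown leave open how large the change from 2-carboxyethyl to 2-carboxyethenyl is. No measurement shown here explains the result.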